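The compounds below may be only part of what the source reports. "The series", "measured", "known", "first", "only" and "open" are said of these compounds alone.

The three measured compounds, all tested in a functional assay for antagonist activity at melanin-concentrating hormone receptor 1 (Homo sapiens) (on this read-out lower numbers stand for stronger inhibition and higher numbers for weaker inhibition), are:

Compound 1 `NCc1ncc([C@]23CC[C@@H](N(CCN4CC[C@H](O)C4)C(=O)Nc4ccc(F)c(C(F)(F)F)c4)C2C3)s1`: 99 nM
Compound 2 `C[C@@H]1CN(CCCN(C(=O)Nc2ccc(F)c(C(F)(F)F)c2)[C@@H]2CC[C@]3(c4cnc(CN)s4)CC23)[C@@H](C)CN1`: 19 nM
Compound 3 `C[C@@H]1CN(CCCN(C(=O)Nc2cc(Cl)nc(Cl)c2)[C@@H]2CC[C@]3(c4cnc(CN)s4)CC23)[C@@H](C)CN1`: 13.1 nM

Among these three, compound 3 carries the lowest number in this assay. Against compound 2 that gap is within the scatter, as a 1.5-fold lower number from compound 2 to compound 3 (0.16 log units; within the scatter) shows, so the two cannot be ordered; against compound 1 the gap is beyond the scatter, the only clear difference in the set.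

Compound 4 `C[C@@H]1CN(CCCN(C(=O)Nc2cc(Cl)nc(Cl)c2)[C@H]2CC[C@@]3(c4cnc(CN)s4)C[C@@H]23)[C@@H](C)CN1` keeps every atom and bond of compound 3; the change is the two compounds have the same atoms and bonds; at least one stereo element is drawn with a configuration in one of them and without one in the other: 3 of 5 stereo elements differ; a stereocentre at a saturated ring carbon is drawn R in compound 3 and S in compound 4; a stereocentre at a saturated ring carbon is drawn S in compound 3 and R in compound 4; a stereocentre at a saturated ring carbon is drawn without a configuration in compound 3 and R in compound 4. In plain words, the shared core is drawn with the opposite handedness at ring carbons, and one ring carbon left undefined in compound 3 is fixed in compound 4.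

Neither measured step touched a stereocentre: a 5.2-fold lower number from compound 1 to compound 2 (0.72 log units; beyond the scatter) exchanged one saturated amine group for another on the chain, and a 1.5-fold lower number from compound 2 to compound 3 (0.16 log units; within the scatter) exchanged the aryl group on the urea nitrogen. Nothing measured here tells how this core responds to a change of handedness, so the step is unpredictable in direction and size from these data alone.

Compound 4 is therefore expected, with low confidence, to give 40 nM in this assay, in a range from 8 nM to 250 nM, which means an expected step of a 3.1-fold higher number from compound 3 to compound 4 (0.48 log units; beyond the scatter).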

Compound 4, inhibition constant: 117 nM
Compound 4: the middle estimate sits 2.9-fold (0.47 log units) below what was measured; the measured number falls inside the stated range.
By their numbers in this assay, from the lowest: compounds 3 and 2 (each within the scatter of the next); then compounds 1 and 4 (each within the scatter of the next).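

Until this point, only the groups attached to the shared core had changed, and swapping the aryl group on the urea nitrogen gave a step within the scatter. Here the atoms and bonds stay the same and only the spatial arrangement at ring carbons differs, yet the read-out moves clearly, with an 8.9-fold higher number from compound 3 to compound 4 (0.95 log units; beyond the scatter) in this assay, so the arrangement of the core matters in this assay and the form drawn in compound 3 gives the stronger inhibition of the pair. The step cannot be divided between the reversed ring carbons and the newly fixed one because of a feature of the two drawings: the fact that one of compounds 3 and 4 is drawn with a defined configuration and the other without, at the place where they differ.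

As far as these compounds go, it remains open how much each of these ring carbons contributes on its own, a question that a version of compound 3 with the undefined carbon fixed could help to answer. From the compounds shown here alone, it is also open whether the same arrangement would carry the same penalty with a morpholine in place of the 2,5-dimethylpiperazin-1-yl group on the chain.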